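The source may report more compounds than this note shows. Statements on the series, on what has been measured and on what is new or still open speak of the compounds shown alone.

Compounds measured so far:
compound 1 `CC(Cn1ccc(-c2ccc(C#N)c(Cl)c2)n1)C(=O)Nc1cc[nH]n1`, compound 2 `C[C@@H](Cn1ccc(-c2ccc(C#N)c(Cl)c2)n1)Nc1ccccc1`.

Compound 1 `CC(Cn1ccc(-c2ccc(C#N)c(Cl)c2)n1)C(=O)Nc1cc[nH]n1` reaches only a limit in a functional assay on LNCaP cells (Homo sapiens) for antiproliferative activity, read by CCK-8 assay, with a stated time of 6 days (on this read-out lower numbers stand for stronger inhibition and higher numbers for weaker inhibition), where compound 1 gives > 30000 nM; this is the limit of > 30000 nM in this assay, at which 1 of the 2 values shown sits. Among the measured compounds shown here, compound 2 `C[C@@H](Cn1ccc(-c2ccc(C#N)c(Cl)c2)n1)Nc1ccccc1` is the one compound with a number: in this assay compound 2 gives 710 nM. Compound 3 `Cc1ccnc(N[C@@H](C)Cn2ccc(-c3ccc(C#N)c(Cl)c3)n2)n1` differs from compound 2 by 4-methylpyrimidin-2-yl in place of phenyl on an amine nitrogen. For the measured compounds named here, no measured pair shows this change, so the expected step from compound 2 to compound 3 is taken as small, toward somewhat stronger inhibition, a 1.8-fold lower number from compound 2 to compound 3 (0.25 log units; within the scatter). Compound 3 is therefore estimated at 400 nM, between 100 nM and 2000 nM.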

Compound 3, half-maximal inhibitory concentration: 1330 nM
Beside the measured number, compound 3's estimate is 3.3-fold (0.52 log units) below it, within the range that was stated.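

In this assay the exchange of phenyl for 4-methylpyrimidin-2-yl on an amine nitrogen gives a 1.9-fold higher number from compound 2 to compound 3 (0.27 log units; within the scatter) and so shows that this position can carry a ring with hetero atoms without a step beyond the scatter. Nothing given here accounts for this step. The compounds shown leave open what a pyrimidin-2-yl without the methyl would give at this nitrogen, and whether an acetyl group or a piperidine ring there would move the number beyond the scatter.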